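Cyclohexylamino versus cyclohexyloxy on two pyrimidine cores

A few compounds are considered here, and "the series" means these few. Any claim that something is new, unique, unknown or untested is made for them only; others in the source may bear on it.

Compound 2 `N#Cc1ccc(Nc2nccc(OC3CCCCC3)n2)cc1` in an ADME assay on MT4 cells (Homo sapiens) for cytotoxicity, read by MTT assay (a higher number here means that more compound is tolerated, a lower number that less compound is tolerated), gives 322000 nM. Compound 1 `N#Cc1ccc(Nc2nccc(NC3CCCCC3)n2)cc1` gives 7330 nM, and the change cyclohexylamino in place of cyclohexyloxy on an aromatic carbon gave a 44-fold lower number from compound 2 to compound 1 (1.64 log units; beyond the scatter). Compound 3 `Cc1cc(OC2CCCCC2)nc(Nc2ccc(C#N)cc2)n1` gives 320 nM; its core differs from that of compound 2 by methyl in place of hydrogen on an aromatic carbon, and that change gave a 1000-fold lower number from compound 2 to compound 3 (3.00 log units; beyond the scatter). Compound 4 `Cc1cc(NC2CCCCC2)nc(Nc2ccc(C#N)cc2)n1` is not yet measured; it differs from compound 3 by cyclohexylamino in place of cyclohexyloxy on an aromatic carbon, the same kind of change as from compound 2 to compound 1, though here the place is also meta to a methyl group (1 heavy atom). If it acts as in the earlier pair, a downward step is expected, an 11-fold lower number from compound 3 to compound 4 (1.03 log units; beyond the scatter), smaller than the earlier one because the methyl step a 1000-fold lower number from compound 2 to compound 3 (3.00 log units; beyond the scatter) already took compound 3 far down. Compound 4 is estimated at 30 nM, between 3 nM and 300 nM.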

Compound 4, half-maximal cytotoxic concentration: 340 nM
For compound 4 the middle estimate is 11-fold (1.05 log units) below the measured one; the whole stated range lies below it.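

On the core carrying the methyl group, cyclohexylamino in place of cyclohexyloxy gives a 1.1-fold higher number from compound 3 to compound 4 (0.03 log units; within the scatter) and so does not repeat in this assay the step seen on the core of compound 2: the same change on two cores in this assay, a 44-fold lower number (1.64 log units; beyond the scatter) from compound 2 to compound 1 and a 1.1-fold higher number (0.03 log units; within the scatter) from compound 3 to compound 4, 47-fold (1.67 log units) apart, beyond the scatter of two such steps.
The methyl change also depends on its partner group, with a 22-fold lower number from compound 1 to compound 4 (1.33 log units; beyond the scatter) on the cyclohexylamino pair, which stands apart from the step on the cyclohexyloxy pair: the same change on two cores in this assay, a 1000-fold lower number (3.00 log units; beyond the scatter) from compound 2 to compound 3 and a 22-fold lower number (1.33 log units; beyond the scatter) from compound 1 to compound 4, 47-fold (1.67 log units) apart, beyond the scatter of two such steps.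
The two changes therefore do not carry independently across these four compounds, but this does not show why, nor whether the same holds for other groups.

Still open, from the compounds shown here alone, is whether an ethyl group in place of the methyl behaves likewise. The same question stands for a piperidine or a straight hexyl chain in place of the cyclohexyl ring.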